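The source may report more compounds than this note shows. Statements on the series, on what has been measured and on what is new or still open speak of the compounds shown alone.

Measured so far:
- compound 1 `O=C(Nc1cccc(-n2cc(-c3ccncc3)c(-c3ccc(Cl)c(O)c3)n2)c1)Nc1cccc(C(F)(F)F)c1`: > 32500 nM
- compound 2 `COc1cc(-c2nn(-c3cccc(NC(=O)Nc4ccc(Cl)c(Cl)c4)c3)cc2-c2ccncc2)ccc1Cl`: > 50000 nM

In a functional assay on SK-OV-3 cells (Homo sapiens) for inhibition, read by sulforhodamine B assay, with a stated time of 48 h (a lower number here means a stronger inhibitor of growth, a higher number a weaker inhibitor of growth), compound 1 gives > 32500 nM, which is a limit of the assay and not a number. Compound 2 gives > 50000 nM in this assay, likewise a limit. Compound 2 thus sits at the limit of > 50000 nM in this assay, at which 1 of the 2 values shown sits, with no number to place it.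

Compound 3 `O=C(Nc1cccc(-n2cc(-c3ccncc3)c(-c3ccc(Cl)c(O)c3)n2)c1)Nc1ccc(Cl)c(Cl)c1` differs from compound 2 by hydrogen in place of methyl on an oxygen on an aromatic ring: methoxy to hydroxy, 4-chloro-3-methoxyphenyl to 4-chloro-3-hydroxyphenyl. Within the data shown here, no measured step covers this change. The expected step is none beyond the scatter: a number no higher from compound 2 to compound 3 (the limit leaves the size open). Compound 3 is estimated at 50000 nM, within 20000 nM to 120000 nM, most probably again reported only as a limit.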

Compound 3, concentration for total growth inhibition: > 32500 nM
Compound 3 was reported as a limit; the forecaster's own chance of this, stated with the estimate: 80%; the middle value lies beyond the limit too.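

In this assay, among these compounds, compound 3 gives > 32500 nM, a limit and not a number, so no step from compound 1 or compound 2 to compound 3 can be read. On these data alone, whether methoxy to hydroxy, or 3,4-dichlorophenyl in place of 3-(trifluoromethyl)phenyl, shifts growth inhibition stays open.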